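Halogenated phenyl variants of a trimethoxyphenyl benzimidazole core

This account rests on a few compounds, and the source may have more. Where it says the series, first, only, none or still open, it means among the compounds named here.

Measured so far in a functional assay on A549 cells (Homo sapiens) for antiproliferative activity, read by MTT assay, with a stated time of 72 h; a higher number here means a weaker inhibitor, a lower number a stronger inhibitor:
- compound 1 `COc1cc(-n2cnc3ccc(-c4cccc(N)c4)cc32)cc(OC)c1OC`: 640 nM
- compound 2 `COc1cc(-n2cnc3ccc(-c4cccc(F)c4)cc32)cc(OC)c1OC`: 5270 nM
- compound 3 `COc1cc(-n2cnc3ccc(-c4cc(F)ccc4F)cc32)cc(OC)c1OC`: 7940 nM

Compound 3 gives the highest number of the three, close to compound 2 and well apart from compound 1; the step from the amino compound runs a 12-fold higher number from compound 1 to compound 3 (1.09 log units; beyond the scatter), while the halogen pair shows a 1.5-fold higher number from compound 2 to compound 3 (0.18 log units; within the scatter). Compound 4 `COc1cc(-n2cnc3ccc(-c4ccccc4Cl)cc32)cc(OC)c1OC` differs from compound 3 by 2-chlorophenyl in place of 2,5-difluorophenyl on an aromatic carbon. Only the halogen-to-halogen step bears directly on this change, and it stayed within the scatter, so no step beyond the scatter is expected for a 1.3-fold lower number from compound 3 to compound 4 (0.12 log units; within the scatter). Compound 4 is therefore estimated at 6000 nM, within 2500 nM to 15000 nM.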

Compound 4, half-maximal inhibitory concentration: > 10000 nM
Compound 4: no number, only a limit; the forecaster's own chance of this, stated with the estimate: 5%; middle value at least 1.6-fold (0.22 log units) from the limit.
By their numbers in this assay, from the lowest: compound 1; then compounds 2 and 3 (each within the scatter of the next). At a limit, above all of these: compound 4.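

Only a limit is available for compound 4 in this assay: the limit of > 10000 nM in this assay, at which 1 of the 4 values shown sits. Putting 2-chlorophenyl in place of the fluorinated rings gives an at least 1.2-fold higher number from compound 3 to compound 4 (0.10 log units; that floor lies within the scatter) and an at least 1.8-fold higher number from compound 2 to compound 4 (0.27 log units; that floor lies within the scatter), so neither floor separates the chloro compound from the two fluoro compounds. The gap to the amino compound is clear, at an at least 15-fold higher number from compound 1 to compound 4 (1.19 log units; beyond the scatter), so all three halogenated phenyl compounds stand well apart from compound 1.

Going by these compounds, the true value of compound 4 stays open. So does whether a hydroxyl or a carboxylic acid in place of the amino group would keep the lower number of compound 1.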